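A Methyl on the Aromatic Ring of Compound 4

A few compounds are considered here, and "the series" means these few. Any claim that something is new, unique, unknown or untested is made for them only; others in the source may bear on it.

The measured compounds and their values:
compound 1, `COc1ccc(-n2cc(NC(=O)c3cccc(NS(=O)(=O)c4ccc(Cl)cc4)c3)cn2)cc1`, gives 19700 nM in a functional assay on HeLa cells (Homo sapiens) for inhibition, read by MTT assay, with a stated time of 48 h; on this read-out lower numbers stand for stronger inhibition and higher numbers for weaker inhibition;
compound 2, `Cn1cc(NC(=O)c2ccc(NS(=O)(=O)c3ccccc3)cc2)cn1`, gives 92800 nM in this assay;
compound 3, `O=C(Nc1cnn(-c2ccccc2)c1)c1ccc(NS(=O)(=O)c2ccccc2)cc1`, gives 37100 nM in this assay.

Compound 3 stands second highest of the three numbers. Its nearest neighbour is compound 1, whose value lies within the scatter of that of compound 3, so no order between the two can be read. Among the measured compounds shown here, its furthest neighbour is compound 2, and the step of a 2.5-fold lower number from compound 2 to compound 3 (0.40 log units; beyond the scatter) is the only measured step here; it follows phenyl in place of methyl on an aromatic nitrogen.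

Compound 4, `Cc1ccc(-n2cc(NC(=O)c3ccc(NS(=O)(=O)c4ccccc4)cc3)cn2)cc1`, is not yet measured in this assay. It differs from compound 3 by methyl in place of hydrogen on an aromatic carbon. For the measured compounds named here, this change sits on the six-membered aromatic ring of carbon only, para to a large group, and no measured step touches that ring; the single measured step concerns the aromatic nitrogen instead and therefore gives no direct guidance. With nothing in the numbers pointing either way, no step beyond the scatter is expected for compound 4 in this assay, so the estimate is a 1.0-fold lower number from compound 3 to compound 4 (0.00 log units; within the scatter). Compound 4 is therefore expected to give about 37000 nM, within the range 15000 nM to 90000 nM.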

Compound 4, half-maximal inhibitory concentration: 27900 nM
Compound 4: the middle estimate sits 1.3-fold (0.12 log units) above what was measured; low and high end bracket the measured number.
By their numbers in this assay, from the lowest: compounds 1, 4 and 3 (each within the scatter of the next); then compound 2.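

Methyl in place of hydrogen, on the six-membered aromatic ring para to a large group, is the first measured change on that ring, and this assay shows a 1.3-fold lower number from compound 3 to compound 4 (0.12 log units; within the scatter), so phenyl to 4-methylphenyl cannot be told apart from no change at this position. On the aromatic nitrogen, the comparison with methyl now has a second member: 4-methylphenyl in place of methyl gives a 3.3-fold lower number from compound 2 to compound 4 (0.52 log units; beyond the scatter), which points the same way as a 2.5-fold lower number from compound 2 to compound 3 (0.40 log units; beyond the scatter), so the lower number seen with phenyl also holds with 4-methylphenyl. No other measurement bears on these numbers, and they offer no explanation for either step.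

The compounds shown leave open whether a group other than methyl at this place, such as an amine or a carboxylic acid, would move the number beyond the scatter. Compound 1 gives 19700 nM but differs from compound 4 in more than one place, so its number cannot be assigned to any single change.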